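From a dichloropyridinyl amide to a morpholinyl hydrazide

The source may hold more compounds than are shown below. What is called first, only, known or untested is meant among the compounds shown, and "the series" means these compounds.

Compound 1 `COc1ccc(-c2ccccc2)c2cc(C(=O)Nc3ccc(F)cc3)oc12` has no result in a functional assay on the whole organism for inhibition, with Mus musculus as the target, at a dose of 10 mg/kg by the oral route; on this read-out higher numbers stand for more inhibition at the one dose given (going by the name of the read-out) and lower numbers for less inhibition: for compound 1 the entry reads "not determined" (no result reported). Compound 2 `COc1ccc(-c2ccccc2)c2cc(C(=O)Nc3c(Cl)cncc3Cl)oc12` holds the only number shown: in this assay compound 2 gives 74%. Compound 3 `COc1ccc(-c2ccccc2)c2cc(C(=O)NN3CCOCC3)oc12` differs from compound 2 in one place (morpholin-4-yl in place of 3,5-dichloropyridin-4-yl on an amide-type nitrogen); the group that leaves is a six-membered aromatic ring, the group that enters a six-membered non-aromatic ring with two hetero atoms. No step between measured compounds is shown, so the size of this change can only be expected: a fall beyond the scatter, with the step from compound 2 to compound 3 estimated at a number 29 percentage points lower from compound 2 to compound 3 (beyond the scatter). Compound 3 is therefore expected to give 45% in this assay, between 15% and 75%.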

Compound 3, a percentage reported as inhibition, in the whole organism at one dose (the size of the read-out at that dose, not a potency): 78%
For compound 3 the middle estimate is 33 percentage points below the measured one, outside the stated range (above it).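

In this assay, putting morpholin-4-yl in place of 3,5-dichloropyridin-4-yl on the amide-type nitrogen gives a number 4 percentage points higher from compound 2 to compound 3 (within the scatter) and so leaves the read-out unmoved at this one dose. This position therefore accepts a six-membered non-aromatic ring as well as a six-membered aromatic ring, without any loss beyond the scatter. Nothing measured here accounts for this match. The compounds shown leave open whether piperidin-1-yl, which lacks the ring oxygen, or an open-chain dimethylamino group on the same nitrogen would read the same. They also leave open how either hydrazide would behave at other doses.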